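This account rests on a few compounds, and the source may have more. Where it says the series, first, only, none or still open, it means among the compounds named here.

In a physicochemical assay for lipophilicity, read by LC-MS, using the shake flask method, at pH 7.4 (on this read-out higher numbers stand for higher lipophilicity and lower numbers for lower lipophilicity), three compounds sharing one core have been measured. Compound 1 (`CC(C)(c1cc(Cl)cc(Cl)c1)N1CCC(COc2cc(F)c(C(=O)NS(C)(=O)=O)cc2C2CC2)CC1`) gives 3.9, compound 2 (`CS(=O)(=O)NC(=O)c1cc(C2CC2)c(OCC2CCN(C(=O)c3cc(Cl)cc(Cl)c3)CC2)cc1F`) gives 0.9, and compound 3 (`CS(=O)(=O)NC(=O)c1cc(C2CC2)c(OCC2CCN(C(c3ccccc3)c3ccccc3)CC2)cc1F`) gives 2.7, the second highest of the three numbers. Compound 4 (`CS(=O)(=O)NC(=O)c1cc(C2CC2)c(OCC2CCN(Cc3ccccc3)CC2)cc1F`) remains unmeasured. Its structure departs from that of compound 3 as follows: hydrogen in place of phenyl on a saturated chain carbon bound to an amine nitrogen in a ring and an aromatic carbon, with hydrogen in place of phenyl on a saturated chain carbon bound to an amine nitrogen in a ring and an aromatic carbon. For the measured compounds named here, the only measured step, a number 3.00 log units lower from compound 1 to compound 2 (beyond the scatter), exchanges a different group and so bears only loosely on this change. A fall beyond the scatter is expected, an estimated a number 1.10 log units lower from compound 3 to compound 4 (beyond the scatter). Compound 4 is estimated at 1.6, with an expected range of 1 to 2.2.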

Compound 4, distribution coefficient: 0.3
Compound 4: middle estimate off by 1.30 log units, on the high side; measured number below the stated range.
By their numbers in this assay, from the lowest: compound 4; then compound 2; then compound 3; then compound 1.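

In this assay, hydrogen in place of phenyl on the saturated chain carbon bound to an amine nitrogen in a ring and an aromatic carbon gives a number 2.40 log units lower from compound 3 to compound 4 (beyond the scatter) for this single exchange, so the read-out responds strongly at this position. Benzyl on the amine nitrogen also gives a number 0.60 log units lower from compound 2 to compound 4 (beyond the scatter) and a number 3.60 log units lower from compound 1 to compound 4 (beyond the scatter) against the two earlier groups, leaving compound 4 the lowest of the four. Nothing available explains the size of this change. On these data alone, whether a methyl group or a carboxylic acid on that chain carbon would read closer to compound 3 or to compound 4 stays open.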